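Adding a Chlorine Atom to a Growth Inhibitor

The compounds below may be only part of what the source reports. "The series", "measured", "known", "first", "only" and "open" are said of these compounds alone.

Of the compounds shown here, two have so far been measured in a functional assay on SF-539 cells (Homo sapiens) for inhibition; a lower number here means a stronger inhibitor of growth, a higher number a weaker inhibitor of growth. Compound 1, `COc1cc(/C=C/C(=O)c2cccc(-n3cc(-c4ccc(Cl)cc4)[nH]c3=O)c2)ccc1O`, gives 1780 nM in this assay. Compound 2, `COc1cc(/C=C/C(=O)c2cccc(-n3cc(-c4ccccc4)[nH]c3=O)c2)cc(OC)c1OC`, gives 1680 nM. Within the data shown here, these two numbers lie within the usual scatter of each other, so the data show no real separation between compound 1 and compound 2; the two structures also differ in more than one place, so no single structural step connects them.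

Compound 3, `COc1cc(/C=C/C(=O)c2cccc(-n3cc(-c4ccc(Cl)cc4)[nH]c3=O)c2)cc(OC)c1OC`, has not yet been measured. It differs from compound 2 in one place: chloro in place of hydrogen on an aromatic carbon. Compound 1 already carries the same chloro group on the same ring, and its value sits within the scatter of compound 2, which carries none, although compound 1 and compound 2 differ elsewhere as well. Nothing here points to a change beyond the scatter, so the expected step is a 1.1-fold lower number from compound 2 to compound 3 (0.05 log units; within the scatter), essentially none. Compound 3 is therefore estimated to give about 1500 nM in this assay, with a plausible range from 700 nM to 3500 nM.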

Compound 3, concentration for 50% growth inhibition: 3490 nM
Compound 3: the middle estimate sits 2.3-fold (0.37 log units) below what was measured; measured number inside the range.
By their numbers in this assay, from the lowest: compounds 2, 1 and 3 (each within the scatter of the next, the first and the last beyond it).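

In this assay, turning phenyl into 4-chlorophenyl gives a 2.1-fold higher number from compound 2 to compound 3 (0.32 log units; beyond the scatter) so this position does respond to the change, and here the added chlorine makes the compound a weaker inhibitor of growth. Among these compounds, this is the first pair in the set that differs in one place only, so it gives the first direct reading of the change, which the earlier two compounds could not give. The step is modest, and nothing available explains why the chlorine has this effect.

As far as these compounds go, a single pair speaks only for this one core, so it remains open whether the same change would also give a weaker inhibitor on the core of compound 1, which carries a different substitution on its other aromatic ring. From the compounds shown here alone, it also remains open how other groups at this place would behave: fluoro, methoxy or an amine might each follow the chlorine, stay level with the hydrogen, or even give a stronger inhibitor of growth.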